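Swapping the methoxypyridyl for a difluorophenyl: stability outlook

The compounds below may be only part of what the source reports. "The series", "measured", "known", "first", "only" and "open" are said of these compounds alone.

Compound 3, `COc1ccc(-c2cc(C3=Nc4c(C(C)(C)C)nn(CCCO)c4C(=O)NC3)ccc2OC)cn1`, gives 2 h in an ADME assay on microsomes from liver (Homo sapiens) for metabolic stability (on this read-out higher numbers stand for a longer-lived compound and lower numbers for a shorter-lived compound), the highest of the three numbers at hand. Compound 2, `COc1ccccc1-c1cc(C2=Nc3c(C(C)(C)C)nn(CCCO)c3C(=O)NC2)ccc1OC`, gives 1.37 h in this assay, and compound 1, `COc1ccc(C2=Nc3c(C(C)(C)C)nn(CCCO)c3C(=O)NC2)cc1-c1ccccc1F`, gives 0.8 h. The steps among them run as a 2.5-fold higher number from compound 1 to compound 3 (0.40 log units; beyond the scatter), a 1.7-fold higher number from compound 1 to compound 2 (0.23 log units; within the scatter) and a 1.5-fold higher number from compound 2 to compound 3 (0.16 log units; within the scatter).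

Compound 4, `COc1ccc(C2=Nc3c(C(C)(C)C)nn(CCCO)c3C(=O)NC2)cc1-c1ccc(F)cc1F`, differs from compound 3 in one place: 2,4-difluorophenyl in place of 6-methoxypyridin-3-yl on an aromatic carbon. The change sits on an aromatic carbon ortho to a methoxy group and meta to a large group. The step that bears on it most directly runs the other way: a 2.5-fold higher number from compound 1 to compound 3 (0.40 log units; beyond the scatter), where compound 1 carries a 2-fluorophenyl. For the measured compounds named here, compound 4 returns to a fluorinated phenyl ring, a 2,4-difluorophenyl rather than the 2-fluorophenyl of compound 1, so a move back toward the number of compound 1 is expected, though a 2,4-difluorophenyl has no precedent among the measured compounds. The expected step is therefore a 2.2-fold lower number from compound 3 to compound 4 (0.35 log units; beyond the scatter). Compound 4 is estimated in this assay at 0.9 h, within a range from 0.5 h to 1.7 h.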

Compound 4, half-life: 2 h
Beside the measured number, compound 4's estimate is 2.2-fold (0.35 log units) below it; the measured number lies above the stated range.
By their numbers in this assay, from the lowest: compounds 1, 2, 3 and 4 (each within the scatter of the next, the first and the last beyond it).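

At this aromatic carbon, ortho to a methoxy group, no change at the digits printed from compound 3 to compound 4 (within the scatter) in this assay shows that a 2,4-difluorophenyl, with no hydrogen-bond acceptors, can stand in for the 6-methoxypyridin-3-yl, and a 1.5-fold higher number from compound 2 to compound 4 (0.16 log units; within the scatter) adds that it also reads alike with the 2-methoxyphenyl. For the compounds shown here, the one clear step belongs to a single added fluoro, a 2.5-fold higher number from compound 1 to compound 4 (0.40 log units; beyond the scatter) and thus a change on the phenyl ring alone, so a fluorinated phenyl ring at this place need not give the low number of compound 1. The compounds at hand offer no measurement that would explain this step.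

Going by these compounds, it remains open whether a chloro or a nitrile in place of the added fluoro would give the same step. On these data alone, it is also open whether an amine or a carboxylic acid on this ring would keep the number of compound 4 in this assay or lower it.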